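From phenylsulfonyl to chloro on the shared core

The source may report more compounds than this note shows. Statements on the series, on what has been measured and on what is new or still open speak of the compounds shown alone.

In a functional assay on the whole organism for inhibition, with Cavia porcellus as the target (on this read-out higher numbers stand for an effect only at larger amounts of compound and lower numbers for an effect already at smaller amounts), compound 1 (`CN(C)/C(=N\C#N)C1=CC(C)(C)Oc2ccc(C#N)cc21`) gives 2140 nM, and compound 2 (`CN(C)/C(=N\C#N)C1=CC(C)(C)Oc2ccc(S(=O)(=O)c3ccccc3)cc21`) gives 3630 nM. These two values lie within the scatter of each other, as a 1.7-fold higher number from compound 1 to compound 2 (0.23 log units; within the scatter) shows. Compound 3 (`CN(C)/C(=N\C#N)C1=CC(C)(C)Oc2ccc(Br)cc21`) is reported only as a limit of the assay, > 31600 nM.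

Compound 4 (`CN(C)/C(=N\C#N)C1=CC(C)(C)Oc2ccc(Cl)cc21`) has not yet been measured. It carries chloro in place of phenylsulfonyl on an aromatic carbon, (chloro in place of phenylsulfonyl on an aromatic carbon). The closest measured change is bromo in place of phenylsulfonyl, an at least 8.7-fold higher number from compound 2 to compound 3 (0.93 log units; beyond the scatter), which is at least modest. Bromo in place of cyano points the same way, with an at least 14-fold higher number from compound 1 to compound 3 (1.16 log units; beyond the scatter), a large step. On these data alone, both steps rest on (the limit of > 31600 nM in this assay, at which 1 of the 3 values shown sits), so their full size stays open. With chloro as the closest neighbour of bromo in this small set, a clear move to a higher number is expected in this assay. The estimated change is a 5.0-fold higher number from compound 2 to compound 4 (0.70 log units; beyond the scatter). Compound 4 is expected at about 18000 nM, with an estimated range of 6000 nM to 50000 nM.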

Compound 4, half-maximal effective concentration: > 31600 nM
Compound 4 was reported as a limit (the forecaster's own chance of this, stated with the estimate: 40%); middle value at least 1.7-fold (0.24 log units) from the limit.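

On this aromatic carbon, chloro in this assay gives an at least 8.7-fold higher number from compound 2 to compound 4 (0.93 log units; beyond the scatter) and, set against cyano, an at least 14-fold higher number from compound 1 to compound 4 (1.16 log units; beyond the scatter) in the same direction. The shift seen with bromo is therefore not confined to that one halogen: among the four compounds, chloro and bromo both stand apart from cyano and phenylsulfonyl, and no compound shown goes against this. Compound 3 and compound 4 cannot be told apart and the step between them cannot be read, because both stop at the same limit of the assay: (the limit of > 31600 nM in this assay, at which 2 of the 4 values shown sit).

On these data alone, whether fluoro would follow chloro and bromo remains open. So does whether an amine or a carboxylic acid on this aromatic carbon would instead fall with cyano and phenylsulfonyl.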